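Swapping Bromo for Methyl on a Shared Core

This account rests on a few compounds, and the source may have more. Where it says the series, first, only, none or still open, it means among the compounds named here.

Compound 1 `O=C(/N=C1\NC2(CCCCO2)CCS1)c1ccc(Br)cc1` carries a bromo group on its aromatic ring. Tested in a functional assay on the whole organism (strain CF-1) with Mus musculus as the target, in the writhing test, with a stated time of 15 min (a lower number here means that less compound is needed, a higher number that more compound is needed for the effect), compound 1 yields only a limit of the assay, > 200 mg/kg, not a number. Compound 2 `COc1cc(C(=O)/N=C2\NC3(CCCCO3)CCS2)cc(OC)c1OC` shares the same core. In this assay compound 2 also reaches only a limit, > 200 mg/kg. Both values therefore sit at the limit of > 200 mg/kg in this assay, at which 2 of the 2 values shown sit, so the two compounds show the same limit and nothing more can be read from them; compound 1 stands at that limit alongside compound 2.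

Compound 3 `Cc1ccc(C(=O)/N=C2\NC3(CCCCO3)CCS2)cc1` has not yet been measured. It differs from compound 1 in one place: methyl in place of bromo on an aromatic carbon. Cut one bond further out, the same difference reads 4-bromophenyl to 4-methylphenyl.

Among the measured compounds shown here, with no measured step between any two compounds, no trend is available. The change from compound 1 to compound 3, a number no higher from compound 1 to compound 3 (the limit leaves the size open), is expected to be none beyond the scatter. In this assay compound 3 is therefore expected to give about 200 mg/kg, somewhere between 70 mg/kg and 500 mg/kg, most likely again as a limit rather than a number.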

Compound 3, dose for half-maximal effect: 60 mg/kg
The estimate for compound 3 lay 3.3-fold (0.52 log units) above the measured number; the whole stated range lies above it.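

Among the compounds shown here, the step from bromo to methyl on this aromatic carbon, para to a large group, is the first change to produce a readable difference: in this assay it gives an at least 3.3-fold lower number from compound 1 to compound 3 (0.52 log units; beyond the scatter). Until now the compounds had shown only a shared ceiling, which left open whether anything on this ring could move the result; now a swap of one heavy atom for another, with the shared core unchanged, is enough to yield a real number. Compound 1 gives > 200 mg/kg, which is a limit and not a number, so the step has a minimum size but no known full size, and such limits remain common in this small set: the limit of > 200 mg/kg in this assay, at which 2 of the 3 values shown sit.

The compounds shown do not tell whether the gain comes from having methyl or from losing bromo, and a plain hydrogen at this place would help to separate the two. Nor do they show how far the trend extends, for example whether a longer chain such as ethyl, an amine or a carboxylic acid at the same carbon would also give a number in this assay.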